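The source may hold more compounds than are shown below. What is called first, only, known or untested is meant among the compounds shown, and "the series" means these compounds.

Measured so far:
compound 1 `CC1=C(C(=O)OC(C)(C)C)C(c2ccoc2)NC(=O)N1` — 11%
compound 2 `CC1=C(C(=O)OCC(C)C)C(c2ccco2)NC(=S)N1` — 7%

In an assay on membranes from CHO cells for displacement of a labelled ligand from adenosine receptor A1 (Homo sapiens), read by scintillation counting, with a stated time of 60 min, tested at 1 uM (a lower number here means less inhibition, a higher number more inhibition at the concentration tested (going by the name of the read-out)), compound 1 gives 11% and compound 2 gives 7%. Compound 2 sits within the scatter of compound 1; both numbers are small. Compound 3 `CC1=C(C(=O)OCc2ccccc2)C(c2ccco2)NC(=S)N1` is compound 2 with phenyl in place of isopropyl on a saturated chain carbon bound to an oxygen next to a carbonyl group. Going by the values given here, no pair of measured compounds shows this change, so nothing fixes its size. With both measured compounds low in this assay, the expected step from compound 2 to compound 3 is a number 2 percentage points higher from compound 2 to compound 3 (within the scatter), none beyond the scatter. Compound 3 is estimated at 9%, with a range of 0% to 25%.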

Compound 3, a percentage reported as inhibition, at one concentration (the size of the read-out at that concentration, not a potency): 32%
Compound 3: middle estimate off by 23 percentage points, on the low side, outside the stated range (above it).
By their numbers in this assay, from the lowest: compounds 2 and 1 (each within the scatter of the next); then compound 3.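

In this assay, going by these compounds alone, phenyl in place of isopropyl on a saturated chain carbon bound to an oxygen next to a carbonyl group gives a number 25 percentage points higher from compound 2 to compound 3 (beyond the scatter), the only step so far that can be read as a change. This place therefore responds to the group it carries, at least for this one change. Nothing available explains the step.

Going by these compounds, whether the aromatic ring or the added carbon count matters stays open. Cyclohexyl or a longer chain at this place would separate the two.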